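The source may hold more compounds than are shown below. What is called first, only, known or untested is meant among the compounds shown, and "the series" means these compounds.

In an assay on CHO cells for antagonist activity at transient receptor potential cation channel subfamily V member 1 (Homo sapiens), read by FLIPR and calcium flux (a lower number here means a stronger inhibitor, a higher number a weaker inhibitor), compound 1 `CC(C(=O)NCc1ccc(C(F)(F)F)nc1C1CCC(C)(C)CC1)c1ccc(NS(C)(=O)=O)c(F)c1` gives 0.4 nM.
Compound 2 `CC1C=C(c2nc(C(F)(F)F)ccc2CNC(=O)C(C)c2ccc(NS(C)(=O)=O)c(F)c2)CCC1` gives 0.2 nM.
Compound 3 `CC(C(=O)NCc1ccc(C(F)(F)F)nc1C1=C[C@H](C)CCC1)c1ccc(NS(C)(=O)=O)c(F)c1` gives 0.1 nM.

Compound 3 is set apart from compound 1 by a 4.0-fold lower number from compound 1 to compound 3 (0.60 log units; beyond the scatter), while its number and that of compound 2 lie within the scatter of each other, a 2.0-fold lower number from compound 2 to compound 3 (0.30 log units; within the scatter). Compound 4 `CCC1CC=C(c2nc(C(F)(F)F)ccc2CNC(=O)C(C)c2ccc(NS(C)(=O)=O)c(F)c2)CC1` differs from compound 3 by 4-ethylcyclohex-1-en-1-yl in place of 3-methylcyclohex-1-en-1-yl on an aromatic carbon. For the measured compounds named here, the steps that bear on this change are those replacing the saturated ring by a cyclohexenyl ring: a 2.0-fold lower number from compound 1 to compound 2 (0.30 log units; within the scatter) and a 4.0-fold lower number from compound 1 to compound 3 (0.60 log units; beyond the scatter). Compound 2 and compound 3 differ only in a drawn configuration (the fact that one of compounds 2 and 3 is drawn with a defined configuration and the other without, at the place where they differ), and their numbers agree within the scatter. Exchanging a methyl for an ethyl on the same ring type is expected to give no step beyond the scatter: a 2.0-fold higher number from compound 3 to compound 4 (0.30 log units; within the scatter). Compound 4 is estimated at 0.2 nM, with a range from 0.07 nM to 0.6 nM.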

Compound 4, inhibition constant: 0.1 nM
For compound 4 the middle estimate is 2.0-fold (0.30 log units) above the measured one; measured number inside the range.
By their numbers in this assay, from the lowest: compounds 3, 4, 2 and 1 (each within the scatter of the next, the first and the last beyond it).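

Two different alkyl-substituted cyclohexenyl rings fit equally well at this position in this assay, with no change at the digits printed from compound 3 to compound 4 (within the scatter) and a 2.0-fold lower number from compound 2 to compound 4 (0.30 log units; within the scatter). The advantage over the saturated ring now appears with a second cyclohexenyl group, a 4.0-fold lower number from compound 1 to compound 4 (0.60 log units; beyond the scatter). Nothing given here explains this tolerance. Because the change alters both the alkyl group and its ring position, the two effects cannot be separated with these compounds. Going by these compounds, how a hydroxyl, an amine or a longer chain such as butyl on the cyclohexenyl ring would behave remains open.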